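The compounds below may be only part of what the source reports. "The series", "measured", "known", "first", "only" and "open" are said of these compounds alone.

Measured compounds:
compound 1 `COc1cc2c(cc1C)NC(=O)/C2=C/c1c(Cl)n(C)c2cc(C)c(OC)cc12`: 26900 nM
compound 2 `COc1cc2c(cc1C)N(C)C(=O)/C2=C/c1c(Cl)n(C)c2cc(C)c(OC)cc12`: 10500 nM
compound 3 `CN(C)c1ccc2[nH]c(Cl)c(/C=C3/C(=O)Nc4ccc(O)cc43)c2c1`: 3800 nM

All three were run in a functional assay on cells (Cancer cell lines, Homo sapiens) for inhibition, with a stated time of 48 h; a lower number here means a stronger inhibitor of growth, a higher number a weaker inhibitor of growth. Compound 1 gives 26900 nM in this assay, compound 2 gives 10500 nM and compound 3 gives 3800 nM. Compound 3 has the lowest number of the three; its gaps to compound 2 and to compound 1 are both beyond the scatter.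

Compound 2 is compound 1 with methyl in place of hydrogen on an amide-type nitrogen in a ring. That change gave a 2.6-fold lower number from compound 1 to compound 2 (0.41 log units; beyond the scatter).

The core of compound 3 differs from the core of compound 1 in a way that is not broken down here; only the two values themselves, given above, are available for comparison.

Compound 4 `CN(C)c1ccc2[nH]c(Cl)c(/C=C3/C(=O)N(C)c4ccc(O)cc43)c2c1` is not yet measured. It is compound 3 with methyl in place of hydrogen on an amide-type nitrogen in a ring, the same change that turned compound 1 into compound 2, made at the same place. Among the compounds with values here, a step of about the same size is expected, a 2.5-fold lower number from compound 3 to compound 4 (0.40 log units; beyond the scatter), resting on a 2.6-fold lower number from compound 1 to compound 2 (0.41 log units; beyond the scatter) as the only precedent. Compound 4 is therefore estimated at 1500 nM in this assay, with a likely range from 600 nM to 4000 nM.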

Compound 4, concentration for 50% growth inhibition: 6030 nM
Compound 4: middle estimate off by 4.0-fold (0.60 log units), on the low side; measured number above the stated range.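

In this assay, methyl in place of hydrogen on an amide-type nitrogen in a ring does not carry over as a fixed step from one core to the other, with a 1.6-fold higher number from compound 3 to compound 4 (0.20 log units; within the scatter) set against the earlier step: the same change on two cores in this assay, a 2.6-fold lower number (0.41 log units; beyond the scatter) from compound 1 to compound 2 and a 1.6-fold higher number (0.20 log units; within the scatter) from compound 3 to compound 4, 4.1-fold (0.61 log units) apart, beyond the scatter of two such steps

On the core of compound 3 the step cannot be told from the scatter, whereas on the core of compound 1 it can, so the earlier step alone is not a safe guide to this change on another core in the series. Within the data shown here, the result does not show why the two steps differ: there are only two pairs, the cores differ in more than one place, and nothing here ties the difference to any single group.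

From the compounds shown here alone, it remains open whether the hydroxy or dimethylamino group, seen here only on the core of compound 3, has any bearing on the outcome of the change. Also open, going by these compounds, is how ethyl, a longer chain or a chain ending in a carboxylic acid on the same nitrogen would read in this assay.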